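Hydroxyphenyl for difluorophenyl on a weakly active core

The source may hold more compounds than are shown below. What is called first, only, known or untested is meant among the compounds shown, and "the series" means these compounds.

Three compounds of this series have been run in a functional assay on HepG2 cells (Homo sapiens) for antiproliferative activity, read by MTT assay, with a stated time of 72 h; on this read-out lower numbers stand for stronger inhibition and higher numbers for weaker inhibition. Compound 1, `O=C1O/C(=C\Cn2cc(-c3cc(F)cc(F)c3)nn2)C(OCc2ccccc2)=C1OCc1ccccc1`, reports only a limit there: in this assay compound 1 gives > 100000 nM. Compound 3, `COc1ccccc1-c1cn(C[C@H](O)[C@H]2OC(=O)C(OCc3ccccc3)=C2OCc2ccccc2)nn1`, also reports only a limit, and in this assay compound 3 gives > 100000 nM. Among the measured compounds shown here, the one numerical value belongs to compound 2, `O=C1O[C@H]([C@@H](O)Cn2cc(CNS(=O)(=O)c3ccc(Cl)cc3F)nn2)C(OCc2ccccc2)=C1OCc1ccccc1`, which in this assay gives 25500 nM. Compound 1 therefore stands at the weak end of what has been measured, at the limit of > 100000 nM in this assay, at which 2 of the 3 values shown sit, so its own position is known only as a limit, not as a number.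

The next compound, compound 4, `O=C1O/C(=C\Cn2cc(-c3cccc(O)c3)nn2)C(OCc2ccccc2)=C1OCc1ccccc1`, differs from compound 1 in one place: 3-hydroxyphenyl in place of 3,5-difluorophenyl on an aromatic carbon. For the measured compounds named here, no step between two measured compounds with a single change of this kind exists, so the size of the step can only be guessed. Compound 4 is expected to stay close to compound 1, with any step an at least 1.2-fold lower number from compound 1 to compound 4 (0.09 log units; that floor lies within the scatter) most likely within the scatter of this assay or giving a modest gain at best. The estimate for compound 4 in this assay is 80000 nM, within a range from 20000 nM to 300000 nM, and a further limit rather than a number is a real possibility.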

Compound 4, half-maximal inhibitory concentration: 61700 nM
Estimate against measurement, compound 4: 1.3-fold (0.11 log units) above; the range from low to high includes it.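

In this assay, among the compounds shown here, 3-hydroxyphenyl in place of 3,5-difluorophenyl, on an aromatic carbon of the five-membered aromatic ring with 3 nitrogen, gives an at least 1.6-fold lower number from compound 1 to compound 4 (0.20 log units; that floor lies within the scatter), the first single-change step at this position. Compound 4 gives a number where compound 1 gives only a limit, so the change, which brings in a hydrogen-bond donor and acceptor absent from 3,5-difluorophenyl, moves the series onto the measurable scale without showing a gain beyond the scatter. The step can be read only as a floor because compound 1 rests on a limit and not on a number: the limit of > 100000 nM in this assay, at which 2 of the 4 values shown sit.

Open, on these data alone, is whether the step follows from the hydroxyl entering or from the fluorines leaving; a plain phenyl or a 3-aminophenyl at this position would separate the two. Also open, as far as these compounds go, is whether the same change reads the same on the core of compound 2, which gives a number in this assay rather than a limit, so that a step there could be sized directly.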